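Chloro in place of fluoro on an aromatic carbon

The compounds below may be only part of what the source reports. "The series", "measured", "known", "first", "only" and "open" are said of these compounds alone.

Within the data shown here, in a functional assay on KG-1 cells (Homo sapiens) for cytotoxicity, read by luminescence and CellTiter-Glo, with a stated time of 3 days (a higher number here means a weaker inhibitor, a lower number a stronger inhibitor), compound 1 (`N#Cc1ccc(NC(=O)c2ccc3cccnc3c2O)c(F)c1`) gives 3260 nM as the higher of the two numbers so far. Among the measured compounds shown here, compound 2 (`O=C(Nc1ccc(C(F)(F)F)cc1)c1ccc(F)cc1O`) gives 740 nM which is lower by more than the scatter, but no single-place step links it to compound 1. Compound 3 (`N#Cc1ccc(NC(=O)c2ccc3cccnc3c2O)c(Cl)c1`) carries chloro in place of fluoro on an aromatic carbon, ortho to a large group and meta to a cyano group (chloro in place of fluoro on an aromatic carbon). For the measured compounds named here, no measured step covers this change. In this assay the expected size is a 1.4-fold lower number from compound 1 to compound 3 (0.13 log units; within the scatter) which stays within the scatter. For compound 3 the estimated value is 2400 nM (expected range 900 nM to 6500 nM).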

Compound 3, half-maximal inhibitory concentration: 3670 nM
Estimate against measurement, compound 3: 1.5-fold (0.18 log units) below, within the range that was stated.
By their numbers in this assay, from the lowest: compound 2; then compounds 1 and 3 (each within the scatter of the next).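

In this assay, chloro in place of fluoro on this aromatic carbon, ortho to a large group and meta to a cyano group, gives a 1.1-fold higher number from compound 1 to compound 3 (0.05 log units; within the scatter) and so leaves the two halogen compounds level at this position. Among these compounds, this is the first single-place step, and it covers only this exchange of one halogen for the other. Nothing measured on these compounds bears on the reason for this result.

Open, on these data alone, is whether an amine or a methoxy group at this position would keep the number at the level of the two halogens. Among the compounds shown here, compound 2 remains linked to this pair by no single-place step, so its lower number cannot be assigned to any one part of the structure.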